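Hydrogen for Methyl on the Aryl Group of Compound 1

The compounds below may be only part of what the source reports. "The series", "measured", "known", "first", "only" and "open" are said of these compounds alone.

Within the data shown here, in a functional assay on HCT-116 cells (Homo sapiens) for antiproliferative activity, read by MTT assay, with a stated time of 72 h (a lower number here means a stronger inhibitor, a higher number a weaker inhibitor), compound 1 `COc1ncc(-c2ccc3c(c2)N(c2ccc(C)cc2)C(=O)CO3)cc1NS(=O)(=O)c1ccc(F)cc1` gives 22700 nM as the only actual number available. Compound 2 `O=C1COc2ccc(-c3cccc(NS(=O)(=O)c4ccc(F)cc4)c3)cc2N1` reaches only a limit of > 40000 nM in this assay and gives no number. Compound 3 `COc1ncc(-c2ccc3c(c2)N(c2ccccc2)C(=O)CO3)cc1NS(=O)(=O)c1ccc(F)cc1` differs from compound 1 by hydrogen in place of methyl on an aromatic carbon with hydrogen in place of methyl on an aromatic carbon, a change of 4-methylphenyl to phenyl. Among the measured compounds shown here, no measured step bears on this change, so no shift beyond the scatter is expected in this assay in either direction. The estimated move is a 1.1-fold higher number from compound 1 to compound 3 (0.02 log units; within the scatter) and no more. Compound 3 is expected at 24000 nM with an estimated range from 12000 nM to 40000 nM in this assay.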

Compound 3, half-maximal inhibitory concentration: 18800 nM
Compound 3: the middle estimate sits 1.3-fold (0.11 log units) above what was measured, and the stated range covers the measured number.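

In this assay, the change of 4-methylphenyl to phenyl gives a 1.2-fold lower number from compound 1 to compound 3 (0.08 log units; within the scatter). Among these compounds, this is the only measured step at this position, and it shows that hydrogen and methyl there cannot be told apart. That reading has limited reach, because compound 2 stands at a limit of the assay and the readable range may end not far from these compounds: the limit of > 40000 nM in this assay, at which 1 of the 3 values shown sits.

As far as these compounds go, what remains open is whether an amine, a carboxylic acid or a longer chain on this aromatic carbon would move the number beyond the scatter. From the compounds shown here alone, it is also open whether the same change would stay as flat on a stronger compound.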